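Swapping a Methoxy for Methylpiperazinyl on the Aryl Ring

The compounds below may be only part of what the source reports. "The series", "measured", "known", "first", "only" and "open" are said of these compounds alone.

Two compounds have been measured so far:
- compound 1, `COc1cccc(-c2cc3[nH]nc(N)c3c(=O)[nH]2)c1`, gives 56%
- compound 2, `COc1ccc(-c2cc3[nH]nc(N)c3c(=O)[nH]2)cc1`, gives 59%

Both were tested in an assay on isolated protein for inhibition of MAP kinase-activated protein kinase 2 (Homo sapiens), read by mobility shift assay, tested at 30 uM; a higher number here means more inhibition at the concentration tested (going by the name of the read-out), a lower number less inhibition. Compound 2 gives the higher of the two numbers, but its nearest neighbour, compound 1, sits only a few points lower, and that gap lies within the scatter of this kind of measurement, so the two cannot be told apart.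

The next compound to be measured is compound 3, `CN1CCN(c2ccc(-c3cc4[nH]nc(N)c4c(=O)[nH]3)cc2)CC1`. It differs from compound 2 in one place: 4-methylpiperazin-1-yl in place of methoxy on an aromatic carbon. For the measured compounds named here, the group that enters is much larger than the one that leaves, and no measured pair shows what such a change does here. Going by the values given here, the only hint is that compounds 1 and 2 give similar numbers with the methoxy in different places on the same ring. The step of a number 4 percentage points lower from compound 2 to compound 3 (within the scatter) is expected to stay within the scatter, with no clear direction. For compound 3 the estimate in this assay is 55%, somewhere between 30% and 80%.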

Compound 3, a percentage reported as inhibition, at one concentration (the size of the read-out at that concentration, not a potency): 55%
The estimate for compound 3 equals the measured number at the digits printed; the range from low to high includes it.
By their numbers in this assay, from the lowest: compounds 3, 1 and 2 (each within the scatter of the next).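

In this assay, swapping methoxy for 4-methylpiperazin-1-yl comes out as a number 4 percentage points lower from compound 2 to compound 3 (within the scatter), so this place on the ring takes a group of 7 heavy atoms with a six-membered non-aromatic ring, in place of one of 2 heavy atoms, without a number that stands apart. Compound 1 and compound 2 both carry methoxy, so they could not show what a much larger group does here. Nothing measured in this set explains the result.

Going by these compounds, whether a carboxylic acid, a simple amine or a morpholine ring at this place would give a number beyond the scatter remains open, as does the effect of 4-methylpiperazin-1-yl at the place of the methoxy in compound 1. These readings come from one concentration, so they give no potency for any of the compounds.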